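Swapping 3,5-Dichlorophenyl for Propyl on a Carbonyl Carbon

The source may hold more compounds than are shown below. What is called first, only, known or untested is meant among the compounds shown, and "the series" means these compounds.

Of the compounds shown here, three sharing one core have been measured in a functional assay on Vero cells (Chlorocebus sabaeus) for inhibition; on this read-out higher numbers stand for weaker inhibition and lower numbers for stronger inhibition. Compound 1 `COc1cc(/C=C/C(=O)c2cccc(NC(=O)c3cccs3)c2)ccc1O` gives 3.98 ug/mL, and compound 3 `COC(=O)C(=O)Nc1cccc(C(=O)/C=C/c2ccc(O)c(OC)c2)c1` gives 3.55 ug/mL, with a 1.1-fold lower number from compound 1 to compound 3 (0.05 log units; within the scatter). Compound 2 `COc1cc(/C=C/C(=O)c2cccc(NC(=O)c3cc(Cl)cc(Cl)c3)c2)ccc1O` gives > 50 ug/mL, which is a limit of the assay and not a number. Compound 2 alone stands at the limit of > 50 ug/mL in this assay, at which 1 of the 3 values shown sits.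

Compound 4 `CCCC(=O)Nc1cccc(C(=O)/C=C/c2ccc(O)c(OC)c2)c1` has not yet been measured. It carries propyl in place of 3,5-dichlorophenyl on a carbonyl carbon, (propyl in place of 3,5-dichlorophenyl on a carbonyl carbon).

Two measured steps change the same place and involve the same departing group. On these data alone, they are an at least 12-fold higher number from compound 1 to compound 2 (1.09 log units; beyond the scatter) and an at least 14-fold lower number from compound 2 to compound 3 (1.14 log units; beyond the scatter), both large, and both are bounded by the limit, so their true sizes remain unknown. The two other groups seen there, thiophen-2-yl and methoxycarbonyl, give numbers within the scatter of each other. On that evidence a large move towards stronger inhibition is expected, with an estimated at least 10-fold lower number from compound 2 to compound 4 (1.00 log units; beyond the scatter) in this assay. Propyl itself has not been tested at this place, so the expectation stays wide. For compound 4 the estimated value is 5 ug/mL, with an expected range of 1.5 ug/mL to 25 ug/mL.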

Compound 4, half-maximal inhibitory concentration: 2.04 ug/mL
The estimate for compound 4 lay 2.5-fold (0.39 log units) above the measured number; the measured number falls inside the stated range.
By their numbers in this assay, from the lowest: compounds 4, 3 and 1 (each within the scatter of the next). At a limit, above all of these: compound 2.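

In this assay, propyl on a carbonyl carbon falls in with the two other groups that keep a measurable number, as a 2.0-fold lower number from compound 1 to compound 4 (0.29 log units; within the scatter) and a 1.7-fold lower number from compound 3 to compound 4 (0.24 log units; within the scatter) both stay within the scatter, so a plain carbon chain serves here as well as thiophen-2-yl, a ring, or methoxycarbonyl, which carries a carbonyl of its own. Alongside these, an at least 24-fold lower number from compound 2 to compound 4 (1.38 log units; beyond the scatter) makes three different groups that each stand far from 3,5-dichlorophenyl, so among the four compounds the large loss belongs to that one group and not to the presence or absence of a ring, since thiophen-2-yl goes against any such reading. On these data alone, the value of compound 2 remains a limit and not a number, so the true size of all its steps stays unknown: the limit of > 50 ug/mL in this assay, at which 1 of the 4 values shown sits.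

The compounds shown leave open whether the loss follows the chlorine atoms or the six-membered carbon ring, which plain phenyl or phenyl with one chlorine at this place would separate. They also leave open how far this tolerance reaches, for instance to a longer chain, an amine or a carboxylic acid on the same carbonyl carbon.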